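Amide-side variation at the carbonyl carbon, toward compound 3

The source may hold more compounds than are shown below. What is called first, only, known or untested is meant among the compounds shown, and "the series" means these compounds.

compound 1 | `COc1cc(/C=C/C(=O)c2cccc(NC(=O)c3cc(Cl)cc(Cl)c3)c2)ccc1O` | 58%
compound 2 | `COc1cc(/C=C/C(=O)c2cccc(NC(=O)C(C)C)c2)ccc1O` | 56%

In a functional assay on HUVEC cells (Homo sapiens) for inhibition, tested at 10 ug/mL (a lower number here means a weaker effect, a higher number a stronger effect of the compound at the concentration tested), compound 1 gives 58% and compound 2 gives 56%. Among the measured compounds shown here, compound 2 stands at the lowest of the two numbers, yet the only measured step, a number 2 percentage points lower from compound 1 to compound 2 (within the scatter), stays within the scatter. Compound 3 `CCOC(=O)C(=O)Nc1cccc(C(=O)/C=C/c2ccc(O)c(OC)c2)c1` differs from compound 2 in one place: ethoxycarbonyl in place of isopropyl on a carbonyl carbon. The step from compound 1 to compound 2 bears on it, since it is the same exchange at the same carbonyl carbon, and it was small. The expected change is therefore a number 1 percentage points lower from compound 2 to compound 3 (within the scatter), nothing beyond the scatter. For compound 3 the estimate is 55%, ranging from 40% to 68%.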

Compound 3, a percentage reported as inhibition, at one concentration (the size of the read-out at that concentration, not a potency): 66%
For compound 3 the middle estimate is 11 percentage points below the measured one; the range from low to high includes it.
By their numbers in this assay, from the lowest: compounds 2, 1 and 3 (each within the scatter of the next).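

The steps read a number 10 percentage points higher from compound 2 to compound 3 (within the scatter) and a number 8 percentage points higher from compound 1 to compound 3 (within the scatter) in this assay and so place ethoxycarbonyl alongside isopropyl and 3,5-dichlorophenyl on this carbonyl carbon. The position on the carbonyl carbon bearing the amide-type nitrogen therefore accepts a group with hydrogen-bond acceptors, and the read-out does not separate it from the earlier groups. Nothing available accounts for the size of these steps.

Open, on these data alone, is whether a carboxylic acid in place of the ethyl ester, or a basic amine on this carbonyl carbon, would move the read-out beyond the scatter.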